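A few compounds are considered here, and "the series" means these few. Any claim that something is new, unique, unknown or untested is made for them only; others in the source may bear on it.

Compound 1 `Cc1cc(C(=O)Nc2nn[nH]n2)nc(-c2ccccc2)c1` gives 88% in a functional assay on the whole organism for inhibition, with Rattus norvegicus as the target, at a dose of 10 mg/kg by the oral route; on this read-out lower numbers stand for a weaker effect and higher numbers for a stronger effect at the one dose given. Compound 2 `CCc1cc(C(=O)Nc2nn[nH]n2)nc(-c2ccccc2)c1` gives 85% in this assay, the lower of the two numbers, and the step of a number 3 percentage points lower from compound 1 to compound 2 (within the scatter) lies within the scatter. Compound 3 `CCCCc1cc(C(=O)Nc2nn[nH]n2)nc(-c2ccccc2)c1` differs from compound 2 by ethyl in place of hydrogen on a saturated chain carbon, two bonds along the chain from an aromatic carbon. Going by the values given here, the only measured step that bears on this change is a number 3 percentage points lower from compound 1 to compound 2 (within the scatter), which stayed within the scatter, so no shift beyond the scatter is expected from compound 2 to compound 3, the expected step being a number 3 percentage points lower from compound 2 to compound 3 (within the scatter). Compound 3 is therefore estimated at 82% in this assay, with a range from 68% to 92%.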

Compound 3, a percentage reported as inhibition, in the whole organism at one dose (the size of the read-out at that dose, not a potency): 100%
The estimate for compound 3 lay 18 percentage points below the measured number; measured number outside the range, above it.
By their numbers in this assay, from the lowest: compounds 2 and 1 (each within the scatter of the next); then compound 3.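

The chain on this carbon does matter in this assay, since ethyl to butyl gives a number 15 percentage points higher from compound 2 to compound 3 (beyond the scatter) and is no longer a change lost in the scatter. Propyl in place of hydrogen on the saturated chain carbon bound to an aromatic carbon likewise gives a number 12 percentage points higher from compound 1 to compound 3 (beyond the scatter) even though compound 1 and compound 2 lie within the scatter of each other, so the effect of the chain is not graded evenly across the three compounds. On these data alone, whether a longer chain than butyl, a carboxylic acid or an amine on that chain holds this read-out stays open. Nothing available explains the rise seen with butyl.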